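Chloro in Place of Hydrogen on the Phenyl Ring

A few compounds are considered here, and "the series" means these few. Any claim that something is new, unique, unknown or untested is made for them only; others in the source may bear on it.

Measured compounds:
Compound 1, `COc1cccc(N2CCN(C(=O)C(C)N3C(=O)CCC3=O)CC2)c1`, gives 0%.
Compound 2, `CC(C(=O)N1CCN(c2ccccc2)CC1)N1C(=O)CCC1=O`, gives 0%.

Both compounds were tested in a functional assay on the whole organism (strain Swiss) with Mus musculus as the target, in the maximal electroshock model, with a stated time of 1 h, at a dose of 100 mg/kg by the intraperitoneal route; on this read-out higher numbers stand for a stronger effect at the one dose given and lower numbers for a weaker effect. Compound 2 stands level with compound 1 at the digits shown: the step of no change at the digits printed from compound 1 to compound 2 (within the scatter) is within the scatter, and the two values give no sign of an effect at the dose used for either compound.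

Compound 3, `CC(C(=O)N1CCN(c2ccc(Cl)cc2)CC1)N1C(=O)CCC1=O`, has not yet been measured. It differs from compound 2 by chloro in place of hydrogen on an aromatic carbon. Within the data shown here, only one measured step bears on this change, the one from compound 1 to compound 2, which swapped a group on the same aromatic ring and left the read-out unchanged. Among the measured compounds shown here, nothing among the measured compounds points to a step beyond the scatter for a second substituent on this ring, so no change beyond the scatter is expected in this assay for compound 3.

Compound 3 is therefore expected to give 0%, within a range of 0% to 15%, an expected step of no change at the digits printed from compound 2 to compound 3 (within the scatter).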

Compound 3, a percentage reported as activity, at one dose (the size of the read-out at that dose, not a potency): 0%
Compound 3: middle estimate and measured number agree at the digits printed, within the range that was stated.
By their numbers in this assay, from the lowest: compounds 1, 2 and 3 (each within the scatter of the next).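

In this assay, chloro in place of hydrogen, on an aromatic carbon para to a large group, gives a step that stays within the scatter (no change at the digits printed from compound 2 to compound 3 (within the scatter)). The earlier compounds shown here showed this only for methoxy and hydrogen, whereas the 4-chlorophenyl group now also stands level with the 3-methoxyphenyl group on the ring amine nitrogen (no change at the digits printed from compound 1 to compound 3 (within the scatter)). All three compounds therefore share one value, so neither adding chloro nor exchanging these two substituted phenyl groups brings any effect into view at the one dose given, and no independent measurement bears on this result.

The compounds shown leave open whether another group at this place on the ring, such as fluoro, trifluoromethyl or an amine, would give a read-out different from that of compound 3. They also leave open whether a change elsewhere in the shared core, such as a longer chain in place of the methyl group, would do so.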